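The source may report more compounds than this note shows. Statements on the series, on what has been measured and on what is new or still open speak of the compounds shown alone.

Compound 3 `Cc1cn(C2CC(N=[N+]=[N-])C(COC(=O)OCCCC(=O)OC(C)(C)C)O2)c(=O)[nH]c1=O` gives 0.267 h in an ADME assay on the whole organism (serum) with Homo sapiens as the target (a higher number here means that the compound lasts longer, a lower number that the compound disappears faster), the higher of the two numbers shown, with compound 1 `Cc1cn(C2CC(N=[N+]=[N-])C(COC(=O)OCCCCCCCCO)O2)c(=O)[nH]c1=O` the nearest at 0.0333 h. For compound 2 `Cc1cn(C2CC(N=[N+]=[N-])C(COC(=O)NCCCO)O2)c(=O)[nH]c1=O` this assay reports only a limit, > 48 h (the limit of > 48 h in this assay, at which 1 of the 3 values shown sits). Compound 4 `Cc1cn(C2CC(N=[N+]=[N-])C(COC(=O)OCCCCO)O2)c(=O)[nH]c1=O` differs from compound 3 by hydroxymethyl in place of tert-butoxycarbonyl on a saturated chain carbon, three bonds along the chain from an oxygen next to a carbonyl group. The step that bears on this is the reverse of the change behind an 8.0-fold higher number from compound 1 to compound 3 (0.90 log units; beyond the scatter), a modest gain; the other measured step, an at least 1400-fold higher number from compound 1 to compound 2 (3.15 log units; beyond the scatter), sits on the carbonyl carbon and not at this position, so it is not taken as a guide. A drop of about that modest size is therefore expected for compound 4, a 6.7-fold lower number from compound 3 to compound 4 (0.82 log units; beyond the scatter). Compound 4 is estimated at 0.04 h, between 0.012 h and 0.15 h.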

Compound 4, half-life: 0.5 h
Compound 4: middle estimate off by 13-fold (1.10 log units), on the low side, outside the stated range (above it).
By their numbers in this assay, from the lowest: compound 1; then compounds 3 and 4 (each within the scatter of the next). At a limit, above all of these: compound 2.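

In this assay the tert-butoxycarbonyl and hydroxymethyl ends at this chain carbon are not told apart (a 1.9-fold higher number from compound 3 to compound 4 (0.27 log units; within the scatter)). Chain length on the hydroxy-ended carbonates does register, with hydroxy in place of 4-hydroxybutyl (a 15-fold higher number from compound 1 to compound 4 (1.18 log units; beyond the scatter)). The value of compound 2 is a limit, so the change from (3-hydroxypropyl)amino to 4-hydroxybutoxy on the carbonyl carbon reads only as a bound, yet a large one (an at least 96-fold lower number from compound 2 to compound 4 (1.98 log units; beyond the scatter)).

On these data alone, whether a carboxylic acid or an amine at the chain end would fall with compound 3 and compound 4 stays open. Also open, as far as these compounds go, is how much of the carbonyl-carbon step belongs to the amino link rather than the chain.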